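The source may hold more compounds than are shown below. What is called first, only, known or untested is meant among the compounds shown, and "the series" means these compounds.

Compounds measured so far:
- Compound 1 `COc1ccc2[nH]c(C(=O)N3CC(=O)N(c4ccccc4)[C@@H](Cc4ccccc4)C3)cc2c1` gives > 30000 nM in an ADME assay on Vero cells (Chlorocebus sabaeus) for cytotoxicity, with a stated time of 7 days; a lower number here means that less compound is tolerated, a higher number that more compound is tolerated; this is a limit of the assay, not a number.
- Compound 2 `COc1cccc(CN2C(=O)CN(C(=O)c3cc4cc(OC)ccc4[nH]3)C[C@@H]2CCc2ccccc2)c1` gives 4500 nM in this assay.
- Compound 3 `COc1ccc2[nH]c(C(=O)N3CC(=O)N(Cc4ccccc4)[C@@H](COC(C)(C)C)C3)cc2c1` gives 78200 nM in this assay.

All three share the same core and differ in the groups on the two saturated ring carbons. Among the two actual numbers, compound 3 stands highest, meaning it is the best tolerated of the pair; compound 2 sits well below it, and the gap between them lies beyond the usual scatter. As far as these compounds go, compound 1 reached only the limit (the limit of > 30000 nM in this assay, at which 1 of the 3 values shown sits), so its true value is unknown.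

Compound 4 `COc1ccc2[nH]c(C(=O)N3CC(=O)N(Cc4ccccc4)[C@@H](CN4C(=O)c5ccccc5C4=O)C3)cc2c1` is the next step from compound 3. The change is a group of 11 heavy atoms (8 carbon, 1 nitrogen, 2 oxygen; one five-membered non-aromatic ring with 1 hetero atom, one six-membered aromatic ring of carbon only) in place of a group of 5 heavy atoms (4 carbon, 1 oxygen; no ring), on a saturated chain carbon bound to a saturated ring carbon. For the measured compounds named here, no step between two measured compounds tests a change of this kind, so no measured reference exists. The expectation is that the number in this assay moves downward, beyond the scatter, toward the region where compound 2 sits with 4500 nM. The estimate for compound 4 is therefore 25000 nM, with a range from 8000 nM to 80000 nM, which corresponds to an expected step of a 3.1-fold lower number from compound 3 to compound 4 (0.50 log units; beyond the scatter).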

Compound 4, half-maximal cytotoxic concentration: 41000 nM
The estimate for compound 4 lay 1.6-fold (0.21 log units) below the measured number; measured number inside the range.
By their numbers in this assay, from the lowest: compound 2; then compounds 4 and 3 (each within the scatter of the next).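

In this assay the step is a 1.9-fold lower number from compound 3 to compound 4 (0.28 log units; within the scatter), so compound 3 and compound 4 cannot be told apart here. This is the only pair shown that differs in one place. It shows that, on a saturated chain carbon bound to a saturated ring carbon, tert-butoxy can be exchanged for a group of 11 heavy atoms, carrying a five-membered non-aromatic ring and a six-membered aromatic ring, without a difference that stands out from the ordinary variation between repeated measurements. No measurement shown bears on why this exchange leaves the two compounds level.

As far as these compounds go, what an amine or a carboxylic acid would do on this same chain carbon stays open, and so does the effect of a plain longer carbon chain there. A single pair also cannot show whether the same exchange would read the same way on another compound with a different group elsewhere on the shared core.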